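This account rests on a few compounds, and the source may have more. Where it says the series, first, only, none or still open, it means among the compounds named here.

Compound 2 `CC(O)CCCC12CCC(c3nnc(-c4ccccc4C(F)(F)F)n3C)(CC1)CC2` has been tested in an assay on CHO-K1 cells for inhibition of 11-beta-hydroxysteroid dehydrogenase type 2 (Homo sapiens), read by scintillation proximity assay; on this read-out higher numbers stand for weaker inhibition and lower numbers for stronger inhibition. In this assay compound 2 gives > 1000 nM, which is a limit of the assay rather than a number. For the measured compounds named here, the only other measured compound is compound 1 `Cn1c(-c2ccccc2C(F)(F)F)nnc1C12CCC(COc3ccc(S(C)(=O)=O)cc3)(CC1)CC2`. In this assay compound 1 gives > 4000 nM, again a limit. Going by the values given here, the single measured step, a step that the two limits leave unreadable from compound 1 to compound 2, cannot be sized, as the limit of > 1000 nM in this assay, at which 1 of the 2 values shown sits, and the limit of > 4000 nM in this assay, at which 1 of the 2 values shown sits, both mark where the values stop. Compound 3 `CCOCC12CCC(c3nnc(-c4ccccc4C(F)(F)F)n3C)(CC1)CC2` has not yet been measured; it differs from compound 2 by ethoxy in place of 3-hydroxybutyl on a saturated chain carbon bound to a saturated ring carbon. With both measured values at limits, no readable step bears on this change, and nothing shown points to inhibition strong enough to yield a number. The expected step, a step that the limit leaves unreadable from compound 2 to compound 3, is none beyond the scatter. Compound 3 is therefore estimated at 3000 nM, with a range from 800 nM to 20000 nM, most likely again reported only as a limit.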

Compound 3, half-maximal inhibitory concentration: > 4000 nM
Compound 3 ended at the assay's limit (the forecaster's own chance of this, stated with the estimate: 80%); at least 1.3-fold (0.12 log units) between middle value and limit.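

No new step can be read: compound 1, compound 2 and compound 3 all stand at limits in this assay, not at numbers. The compounds shown leave open how strongly each one inhibits, and whether changing the group on the shared core alters that at all.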